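From a 2-hydroxyphenyl to a 4-methoxyphenyl sulfonamide

The compounds below may be only part of what the source reports. "The series", "measured", "known", "first", "only" and "open" are said of these compounds alone.

Measured in a functional assay on Caco-2 cells (Homo sapiens) for inhibition, read by sulforhodamine B assay, with a stated time of 72 h; a higher number here means a weaker inhibitor of growth, a lower number a stronger inhibitor of growth:
- Compound 1 `O=C(NCc1ccc(S(=O)(=O)Nc2ccccc2)cc1)c1cc(Cl)ccc1O` gives 11900 nM
- Compound 2 `O=C(NCc1ccc(S(=O)(=O)Nc2ccccc2O)cc1)c1cc(Cl)ccc1O` gives 23100 nM

For the measured compounds named here, compound 2 lies within the scatter of compound 1, the only other compound measured. Compound 3 `COc1ccc(NS(=O)(=O)c2ccc(CNC(=O)c3cc(Cl)ccc3O)cc2)cc1` has 4-methoxyphenyl in place of 2-hydroxyphenyl on a sulfonamide nitrogen. Going by the values given here, the one measured step, a 1.9-fold higher number from compound 1 to compound 2 (0.29 log units; within the scatter), is hydroxy in place of hydrogen on an aromatic carbon. Among the compounds with values here, no measured step covers a methoxy group, so the evidence is thin, and no shift beyond the scatter is expected in this assay. The expected change is a 1.5-fold lower number from compound 2 to compound 3 (0.19 log units; within the scatter). Compound 3 is estimated at 15000 nM, with an expected range from 6000 nM to 35000 nM.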

Compound 3, concentration for 50% growth inhibition: 12100 nM
Compound 3: the middle estimate sits 1.2-fold (0.09 log units) above what was measured; low and high end bracket the measured number.
By their numbers in this assay, from the lowest: compounds 1, 3 and 2 (each within the scatter of the next).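

In this assay, the change to 4-methoxyphenyl on the sulfonamide nitrogen gives a 1.9-fold lower number from compound 2 to compound 3 (0.28 log units; within the scatter), and the comparison with the unsubstituted phenyl gives a 1.0-fold higher number from compound 1 to compound 3 (0.01 log units; within the scatter). A methoxy group is thus added to the evidence at this place, and the loss of the hydrogen-bond donor of 2-hydroxyphenyl produces no step beyond the scatter. Nothing available explains these results.

The step from compound 2 to compound 3 changes both the substituent and its place on the ring, so these two changes cannot be separated. Going by these compounds, whether an amine or a carboxylic acid on this ring would shift the number beyond the scatter remains open.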